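Swapping 4-Methylphenyl for 4-Cyanobenzyl in a Weak Series

The source may hold more compounds than are shown below. What is called first, only, known or untested is meant among the compounds shown, and "the series" means these compounds.

Compound 1 `CC(C)n1ncc2c(C(=O)Nc3cccnc3)cccc21`: > 40000 nM
Compound 2 `Cc1ccc(-n2cc(CNC(=O)c3cccc4c3cnn4C(C)C)nn2)cc1`: 39000 nM

Both measured compounds were tested in a functional assay on PC-3 cells (Homo sapiens) for inhibition, read by MTT assay, with a stated time of 72 h; a higher number here means a weaker inhibitor, a lower number a stronger inhibitor. For compound 1 the value > 40000 nM is a limit of the assay rather than a number. That limit is where one of the two values shown sits (the limit of > 40000 nM in this assay, at which 1 of the 2 values shown sits). For the measured compounds named here, compound 2 gives 39000 nM in this assay, which is the only real number in the set.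

Compound 3 `CC(C)n1ncc2c(C(=O)NCc3cn(Cc4ccc(C#N)cc4)nn3)cccc21` has not yet been measured. It differs from compound 2 in a single place: 4-cyanobenzyl in place of 4-methylphenyl on an aromatic nitrogen. Going by the values given here, no step between measured compounds is available, so the effect of this change cannot be read from the data; it can only be judged from where compound 2 stands. With compound 2 already at 39000 nM, no step beyond the usual scatter is expected in either direction, and the step estimated here is a 1.3-fold lower number from compound 2 to compound 3 (0.11 log units; within the scatter). Compound 3 is therefore expected to give about 30000 nM in this assay. For compound 3 the expected range runs from 10000 nM to 80000 nM, with a real chance that the assay returns only a limit.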

Compound 3, half-maximal inhibitory concentration: 18200 nM
Beside the measured number, compound 3's estimate is 1.6-fold (0.22 log units) above it, and the stated range covers the measured number.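

In this assay, for the compounds shown here, the substituent on the aromatic nitrogen of the five-membered ring proves able to move the read-out: 4-cyanobenzyl in place of 4-methylphenyl gives a 2.1-fold lower number from compound 2 to compound 3 (0.33 log units; beyond the scatter) and provides the first step in this set that can be read at all. The step is modest, and compound 3 at 18200 nM remains a weak inhibitor, so this position accepts the larger 4-cyanobenzyl group without loss, but this one change does not lift the series out of its weak range. Compound 1 is still only a limit of the assay, not a number, and that limit continues to bound this small set: the limit of > 40000 nM in this assay, at which 1 of the 3 values shown sits.

This single step does not separate the contribution of the nitrile from that of the benzyl carbon that links the aromatic ring to the ring nitrogen, a question that a plain benzyl or a 4-cyanophenyl group on the same nitrogen would address. It also leaves open how a group of a different kind at this position, such as an amine or a carboxylic acid, would read in this assay.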